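From compound 2 to compound 3: losing the nitro group

The source may hold more compounds than are shown below. What is called first, only, known or untested is meant among the compounds shown, and "the series" means these compounds.

Compound 1 `C/C=C1/[C@H](O[C@@H]2O[C@H](CO)[C@@H](O)[C@H](O)[C@H]2O)OC=C(C(=O)OC)[C@H]1CC(=O)OCc1ccc2c(c1)OCCO2` and compound 2 `C/C=C1/[C@H](O[C@@H]2O[C@H](CO)[C@@H](O)[C@H](O)[C@H]2O)OC=C(C(=O)OC)[C@H]1CC(=O)OCCc1ccc([N+](=O)[O-])cc1` share a core and differ in one place. In a functional assay on SK-BR-3 cells (Homo sapiens) for antiproliferative activity, read by MTT assay, with a stated time of 72 h (on this read-out higher numbers stand for weaker inhibition and lower numbers for stronger inhibition), compound 1 gives > 15000 nM, which is a limit and not a number. In this assay compound 2 gives > 20000 nM, which is likewise a limit. For the measured compounds named here, compound 2 therefore has no exact value, and the only other value shown is also a limit.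

Compound 3 `C/C=C1/[C@H](O[C@@H]2O[C@H](CO)[C@@H](O)[C@H](O)[C@H]2O)OC=C(C(=O)OC)[C@H]1CC(=O)OCCc1ccccc1` has hydrogen in place of nitro on an aromatic carbon, para to a large group, turning 2-(4-nitrophenyl)ethyl into phenethyl (hydrogen in place of nitro on an aromatic carbon). Going by the values given here, the only measured step is a step that the two limits leave unreadable from compound 1 to compound 2. It concerns the same side of the molecule but gives no size to carry over.

The expectation therefore rests on compound 2 at > 20000 nM, and no step beyond the scatter is expected in this assay. The estimated change is a step that the limit leaves unreadable from compound 2 to compound 3, and another limit is the likeliest report. For compound 3 the expected value is 25000 nM, with an estimated range from 10000 nM to 60000 nM.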

Compound 3, half-maximal inhibitory concentration: 11000 nM
Beside the measured number, compound 3's estimate is 2.3-fold (0.36 log units) above it; low and high end bracket the measured number.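

For the compounds shown here, compound 3 is the first compound here with an exact number in this assay, which gives this side of the molecule a fixed point for later comparisons. Hydrogen in place of nitro on the aromatic carbon gives an at least 1.8-fold lower number from compound 2 to compound 3 (0.25 log units; that floor lies within the scatter), and this can be stated only as a floor because the starting value is a limit and not a number: the limit of > 20000 nM in this assay, at which 1 of the 3 values shown sits. Benzyl in place of 2,3-dihydro-1,4-benzodioxin-6-yl gives an at least 1.3-fold lower number from compound 1 to compound 3 (0.13 log units; that floor lies within the scatter), which is again only a floor because its starting value is also a limit: the limit of > 15000 nM in this assay, at which 1 of the 3 values shown sits.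

Going by these compounds, whether either change truly moves the number therefore stays open, and the step between the two limits, from compound 1 to compound 2, cannot be read. Also open, on these data alone, is what an amine or a carboxylic acid on that aromatic carbon, or a chain longer than phenethyl, would do to the exact number of compound 3.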